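Benzyl in Place of Fluorophenyl on the Shared Core

The source may report more compounds than this note shows. Statements on the series, on what has been measured and on what is new or still open speak of the compounds shown alone.

Among the compounds with values here, compound 1 `C=C(Br)C(=O)Nc1cccc(-c2cn3nc(-c4ccc(F)cc4)sc3n2)c1` is the only compound with a numerical result in a functional assay on FM3A cells (Mus musculus) for inhibition, read by cell counting, with a stated time of 2 days (on this read-out higher numbers stand for weaker inhibition and lower numbers for stronger inhibition), where compound 1 gives 610 nM. Compound 2 `CCOc1ccc(-c2nn3cc(-c4cccc(N)c4)nc3s2)cc1` reaches only a limit of this assay, recorded as >= 250000 nM. Compound 3 `C=C(Br)C(=O)Nc1cccc(-c2cn3nc(Cc4ccccc4)sc3n2)c1` differs from compound 1 in one place: benzyl in place of 4-fluorophenyl on an aromatic carbon. Within the data shown here, no measured pair shows this same change, so the size of the step is not known from the data. Compound 3 is expected to be somewhat weaker, with an estimated 2000 nM in this assay, ranging from 300 nM to 15000 nM. The expected step is a 3.3-fold higher number from compound 1 to compound 3 (0.52 log units; beyond the scatter) in this assay.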

Compound 3, half-maximal inhibitory concentration: 3000 nM
Compound 3: the middle estimate sits 1.5-fold (0.18 log units) below what was measured, within the range that was stated.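

In this assay, replacing 4-fluorophenyl with benzyl on this aromatic carbon gives a 4.9-fold higher number from compound 1 to compound 3 (0.69 log units; beyond the scatter). Within the data shown here, this is the first measured step at this position, and it shows that the position accepts benzyl with a modest loss, leaving a numerical result rather than a limit. Nothing measured here gives a cause for this step.

Unsubstituted phenyl would show whether the step follows from losing the fluorine or from gaining the benzyl carbon. Going by these compounds, how an amine, a carboxylic acid or a longer chain would behave at this position remains open.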